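A few compounds are considered here, and "the series" means these few. Any claim that something is new, unique, unknown or untested is made for them only; others in the source may bear on it.

Compound 1 `Cc1cccc(C#Cc2ccc3c(n2)CCN(C)C3=O)c1`: 820 nM
Compound 2 `Cc1cccc(C#Cc2ccc3c(n2)CCN(C(C)C)C3=O)c1`: 510 nM
Compound 3 `Cc1cccc(C#Cc2ccc3c(n2)CCN(C2CCCC2)C3=O)c1`: 670 nM

Three compounds share one core and differ only in the group on the amide-type nitrogen in the ring. In an assay on HEK293 cells for displacement of a labelled ligand from metabotropic glutamate receptor 5 (Homo sapiens), with a stated time of 2 h (on this read-out higher numbers stand for weaker inhibition and lower numbers for stronger inhibition), compound 1 gives 820 nM, compound 2 gives 510 nM and compound 3 gives 670 nM. Compound 3 stands second highest of the three numbers, but the steps of a 1.2-fold lower number from compound 1 to compound 3 (0.09 log units; within the scatter), a 1.3-fold higher number from compound 2 to compound 3 (0.12 log units; within the scatter) and a 1.6-fold lower number from compound 1 to compound 2 (0.21 log units; within the scatter) all lie within the scatter, so the three cannot be ordered among themselves.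

Compound 4 `O=C1c2ccc(C#Cc3cccc(Cl)c3)nc2CCN1C1CCCC1` keeps the cyclopentyl of compound 3 and changes the other end of the molecule: chloro in place of methyl on an aromatic carbon. The methyl on the six-membered aromatic ring of carbon only, meta to a large group, leaves and a chloro enters; cut one bond further out, 3-methylphenyl becomes 3-chlorophenyl. Among the measured compounds shown here, none of the measured steps touches this ring: all three concern the amide-type nitrogen, and they were small. For the measured compounds named here, no step therefore bears directly on the change, and the expectation rests on the value of compound 3 alone. The step to compound 4 in this assay is expected to be a 1.1-fold lower number from compound 3 to compound 4 (0.05 log units; within the scatter), not beyond the scatter. Compound 4 is estimated at 600 nM, within a range from 250 nM to 1500 nM.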

Compound 4, inhibition constant: 5230 nM
Beside the measured number, compound 4's estimate is 8.7-fold (0.94 log units) below it; the measured number lies above the stated range.
By their numbers in this assay, from the lowest: compounds 2, 3 and 1 (each within the scatter of the next); then compound 4.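

In this assay, among the compounds shown here, the exchange of 3-methylphenyl for 3-chlorophenyl gives a 7.8-fold higher number from compound 3 to compound 4 (0.89 log units; beyond the scatter), the only step in the set that lies beyond the scatter. The steps among methyl, isopropyl and cyclopentyl on the amide-type nitrogen in the ring could not separate compounds 1, 2 and 3, whereas replacing one heavy atom with another on the aromatic carbon, meta to a large group, weakens inhibition measurably, so with cyclopentyl on the nitrogen this position does not tolerate every small exchange. Nothing available accounts for why chloro reads so differently from methyl here.

Because the chloro exchange is shown only with cyclopentyl on the nitrogen, it remains open whether a similar step would appear with methyl or isopropyl there. As far as these compounds go, it also remains open how this position would respond to other groups, such as fluoro, methoxy or nitrile, and whether a plain hydrogen there would read closer to methyl or to chloro.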